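Phenyl in place of methylpyrrolidinyl on the shared core

The source may hold more compounds than are shown below. What is called first, only, known or untested is meant among the compounds shown, and "the series" means these compounds.

Of the compounds shown here, two have been measured in an assay on isolated protein for binding affinity to Leucine-rich repeat serine/threonine-protein kinase 2 variant G2019S (Homo sapiens), read by TR-FRET and LanthaScreen, with a stated time of 2 h; on this read-out lower numbers stand for stronger inhibition and higher numbers for weaker inhibition. Compound 1 `Cn1c(N2CCCC2)c(C#N)c2c(N)ncnc21` gives 125 nM, while compound 2 `C[C@@H]1CCCN1c1c(C#N)c2c(N)ncnc2n1C` gives 0.7 nM. Among the measured compounds shown here, the single change between them, a 180-fold lower number from compound 1 to compound 2 (2.25 log units; beyond the scatter), is the only measured step available. Compound 2 therefore has the lowest of the two numbers, its nearest neighbour being compound 1 with a far higher number.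

Compound 3 `Cn1c(-c2ccccc2)c(C#N)c2c(N)ncnc21` differs from compound 2 by phenyl in place of 2-methylpyrrolidin-1-yl on an aromatic carbon. For the measured compounds named here, no measured step covers exactly this exchange; the step from compound 1 to compound 2 shows only how much the methyl on the saturated ring contributes, and that whole ring, methyl included, now leaves. Since compound 2 owes its low number to a 180-fold lower number from compound 1 to compound 2 (2.25 log units; beyond the scatter), the loss of that group is expected to raise the number markedly in this assay, by about a 210-fold higher number from compound 2 to compound 3 (2.33 log units; beyond the scatter). Compound 3 is thus estimated at 150 nM, within a range from 15 nM to 1500 nM.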

Compound 3, inhibition constant: 33 nM
Estimate against measurement, compound 3: 4.5-fold (0.66 log units) above, and the stated range covers the measured number.
By their numbers in this assay, from the lowest: compound 2; then compound 3; then compound 1.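

In this assay, replacing pyrrolidin-1-yl with phenyl on this aromatic carbon gives a 3.8-fold lower number from compound 1 to compound 3 (0.58 log units; beyond the scatter) and so shows that the position accepts a six-membered aromatic ring of carbon only, with a modest gain over the unmethylated saturated ring. The same phenyl in place of 2-methylpyrrolidin-1-yl gives a 47-fold higher number from compound 2 to compound 3 (1.67 log units; beyond the scatter) and leaves the methylated saturated ring as the group with the lowest number of the three shown at this position. Nothing measured here explains either step.

The compounds shown leave open whether a methyl, a methoxy group or an amine on the phenyl ring would lower the number as the methyl on the saturated ring did. They also leave open how a larger saturated ring such as piperidine would compare at this position.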